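The compounds below may be only part of what the source reports. "The series", "measured", "known", "first", "only" and "open" are said of these compounds alone.

Compound 1 `CCN(CC)c1ccc(-c2cccc(Cl)c2)nn1` | > 25000 nM
Compound 2 `CCN(CC)c1ccc(-c2cccc(C#N)c2)nn1` | > 25000 nM

In a functional assay on Huh-7 cells (Homo sapiens) for antiproliferative activity, with a stated time of 48 h (a higher number here means a weaker inhibitor, a lower number a stronger inhibitor), compound 1 gives > 25000 nM as a limit and not as a number. Compound 2 gives > 25000 nM as a limit too, so it stands without a number of its own. The two compounds thus share one position (the limit of > 25000 nM in this assay, at which 2 of the 2 values shown sit), and neither offers a measured potency to build on.

Compound 3 `CCOC(=O)c1cccc(-c2ccc(N(CC)CC)nn2)c1` differs from compound 2 by a single swap (ethoxycarbonyl in place of cyano on an aromatic carbon), with ethoxycarbonyl in place of cyano on an aromatic carbon, meta to a large group. Among the compounds with values here, the only measured step is a step that the two limits leave unreadable from compound 1 to compound 2 and it gives no size or direction to carry over. Nothing beyond the scatter is therefore expected in this assay, and the estimated step is a number no higher from compound 2 to compound 3 (the limit leaves the size open) on that reading. Compound 3 is expected to stay close to the limit that compound 2 reached (> 25000 nM), and the assay may report only a limit again. For compound 3 the estimate is 25000 nM (expected range 10000 nM to 50000 nM), a figure that remains an expectation until measured.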

Compound 3, half-maximal inhibitory concentration: > 25000 nM
Compound 3: a limit, no number; the forecaster's own chance of this, stated with the estimate: 70%; the middle value sits exactly at the limit.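

In this assay compound 3 gives > 25000 nM, a limit and not a number. Within the data shown here, no step among compound 1, compound 2 and compound 3 can be read, and all three share one position: the limit of > 25000 nM in this assay, at which 3 of the 3 values shown sit. The compounds shown leave open how potent each one is and whether chloro, cyano and ethoxycarbonyl differ at all in this measurement.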